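The compounds below may be only part of what the source reports. "The series", "measured", "known", "first", "only" and "open" are said of these compounds alone.

Measured so far:
compound 1, `CN(C)CCCN(/N=N/c1cc(F)ccc1F)c1cccc(C(F)(F)F)c1` — 16000 nM
compound 2, `FC(F)(F)c1cccc(N/N=N/c2ccccc2)c1` — > 100000 nM

In an ADME assay on MT4 cells (Homo sapiens) for cytotoxicity, read by MTT assay, with a stated time of 96 h (a lower number here means that less compound is tolerated, a higher number that more compound is tolerated), compound 1 gives 16000 nM. For compound 2 only a limit of the assay is recorded, > 100000 nM. Compound 2 therefore stands at the limit of > 100000 nM in this assay, at which 1 of the 2 values shown sits.

Compound 3, `CN(C)CCCN(/N=N/c1ccccc1)c1cccc(C(F)(F)F)c1`, differs from compound 2 by 3-(dimethylamino)propyl in place of hydrogen on a nitrogen on an aromatic ring. Within the data shown here, no step between two measured compounds is available for this change. Compound 1, which carries the same 3-(dimethylamino)propyl group, gives 16000 nM, a numbered value rather than a limit. Expected is therefore an at least 5.0-fold lower number from compound 2 to compound 3 (0.69 log units; beyond the scatter), a fall in tolerated concentration beyond the usual scatter. Compound 3 is estimated at 20000 nM, with a range from 6000 nM to 70000 nM.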

Compound 3, half-maximal cytotoxic concentration: 14000 nM
For compound 3 the middle estimate is 1.4-fold (0.15 log units) above the measured one, within the range that was stated.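

In this assay, among these compounds, 3-(dimethylamino)propyl in place of hydrogen on the nitrogen gives an at least 7.1-fold lower number from compound 2 to compound 3 (0.85 log units; beyond the scatter), the first direct reading of this change. Phenyl in place of 2,5-difluorophenyl gives a 1.1-fold lower number from compound 1 to compound 3 (0.06 log units; within the scatter), so with the chain present this ring change stays within the scatter. Compound 2 has a limit of the assay rather than a number, and the step from it is a bound only: the limit of > 100000 nM in this assay, at which 1 of the 3 values shown sits.

Open, from the compounds shown here alone, is whether a shorter or longer chain at this nitrogen gives a similar number. Also open, going by these compounds, is whether a primary amine at the chain end does the same.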